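Thiophen-2-yl in Place of 2-Methoxyphenyl: An Estimate

The compounds below may be only part of what the source reports. "The series", "measured", "known", "first", "only" and "open" are said of these compounds alone.

Measured compounds:
compound 1 `COc1ccccc1/C=C/C(=O)/C=C/c1ccc(OCc2cn(CCCOc3cc(=O)oc4ccccc34)nn2)c(OC)c1` — 57%
compound 2 `COc1cc(/C=C/C(=O)/C=C/c2cccs2)ccc1OCc1cn(CCCCOc2cc(=O)oc3ccccc23)nn1` — 40%

In a functional assay on COLO 205 cells (Homo sapiens) for inhibition, read by sulforhodamine B assay, with a stated time of 48 h, tested at 50 uM (a lower number here means less inhibition of growth, a higher number more inhibition of growth at the concentration tested), compound 1 gives 57%, the higher of the two numbers recorded. Compound 2 gives 40% in the same test, and the gap between the two compounds lies beyond the usual scatter of repeated measurements, so compound 1 stands clearly above compound 2.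

Compound 3 `COc1cc(/C=C/C(=O)/C=C/c2cccs2)ccc1OCc1cn(CCCOc2cc(=O)oc3ccccc23)nn1` has not yet been measured. It differs from compound 1 in one place: thiophen-2-yl in place of 2-methoxyphenyl on a double-bonded chain carbon bound to a double-bonded chain carbon. Among the measured compounds shown here, no pair of measured compounds differs in only one place, so the size of this kind of step is not known from the data. Compound 2 also carries thiophen-2-yl at that end of the chain, but it differs from compound 3 elsewhere as well, so its value can only serve as a loose pointer. On that basis, the account expects a moderate fall in this assay from compound 1 to compound 3, beyond the scatter, described as a number 12 percentage points lower from compound 1 to compound 3 (beyond the scatter). For compound 3 the expected value is 45%, with a range from 30% to 60%.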

Compound 3, percent growth inhibition at one concentration: 55%
Estimate against measurement, compound 3: 10 percentage points below, and the stated range covers the measured number.
By their numbers in this assay, from the lowest: compound 2; then compounds 3 and 1 (each within the scatter of the next).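

In this assay, the swap of 2-methoxyphenyl for thiophen-2-yl can now be read on its own, and the step is a number 2 percentage points lower from compound 1 to compound 3 (within the scatter). On a double-bonded chain carbon bound to a double-bonded chain carbon, a five-membered aromatic ring with one sulfur atom therefore stands in for a six-membered carbon ring bearing a methoxy group, with no change in growth inhibition that this test can separate from scatter, although the group falls from 8 heavy atoms to 5. No measurement shown here accounts for this result, which rests on a single pair of compounds at one concentration in one cell line.

Compound 2 gives 40% and compound 3 gives 55%, and since these two differ only in the length of one chain, the pair points to that chain as a second place to examine, though a single pair cannot establish a trend. The compounds shown also leave open how this place would respond to a furan-2-yl ring, an unsubstituted phenyl ring or a phenyl ring carrying an amine or a carboxylic acid.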